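Nitro to methoxy on a furanyl-bearing core: expected effect

The source may report more compounds than this note shows. Statements on the series, on what has been measured and on what is new or still open speak of the compounds shown alone.

Measured so far:
Compound 1, `CCCc1n[nH]c2c(=O)n(NC(=O)c3ccccc3)c(-c3cccc([N+](=O)[O-])c3)nc12`, gives 27.8% in a functional assay on DU-145 cells (Homo sapiens) for cytotoxicity, read by sulforhodamine B assay, with a stated time of 2 days, tested at 100 uM; on this read-out higher numbers stand for more inhibition at the one concentration tested (going by the name of the read-out) and lower numbers for less inhibition.
Compound 2, `CCCc1n[nH]c2c(=O)n(NC(=O)c3ccccc3)c(-c3cccc(OC)c3)nc12`, gives 23.6% in this assay.
Compound 3, `O=C(Nn1c(-c2cccc([N+](=O)[O-])c2)nc2c(-c3ccco3)n[nH]c2c1=O)c1ccccc1`, gives 16.1% in this assay.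

Compound 1 and compound 2 differ only by methoxy in place of nitro on an aromatic carbon, and this change gave a number 4.2 percentage points lower from compound 1 to compound 2 (within the scatter). Compound 3 stands on a core that differs from that of compound 1 by furan-2-yl in place of propyl on an aromatic carbon, a change that gave a number 11.7 percentage points lower from compound 1 to compound 3 (beyond the scatter). Compound 4, `COc1cccc(-c2nc3c(-c4ccco4)n[nH]c3c(=O)n2NC(=O)c2ccccc2)c1`, is not yet measured; it differs from compound 3 by methoxy in place of nitro on an aromatic carbon, the same change that turned compound 1 into compound 2, made on the same kind of place.

Because the step of a number 4.2 percentage points lower from compound 1 to compound 2 (within the scatter) was small, a similar step is expected in this assay from compound 3 to compound 4, namely a number 4.1 percentage points lower from compound 3 to compound 4 (within the scatter). Nothing among these three compounds suggests that the furan-2-yl core should answer this change differently. Compound 4 is therefore estimated at 12%, with a plausible range from 2% to 22%.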

Compound 4, a percentage reported as inhibition, at one concentration (the size of the read-out at that concentration, not a potency): 50.5%
Compound 4: the middle estimate sits 38.5 percentage points below what was measured, outside the stated range (above it).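

On the furan-2-yl core, methoxy in place of nitro in this assay gave a result (a number 34.4 percentage points higher from compound 3 to compound 4 (beyond the scatter)) that did not carry over from the propyl core, so the size and direction of this change depend on the core in these two pairs: the same change on two cores in this assay, a number 4.2 percentage points lower (within the scatter) from compound 1 to compound 2 and a number 34.4 percentage points higher (beyond the scatter) from compound 3 to compound 4, 38.6 percentage points apart, beyond the scatter of two such steps.

Read the other way, furan-2-yl in place of propyl also gave a different result once the 3-methoxyphenyl group was present (a number 26.9 percentage points higher from compound 2 to compound 4 (beyond the scatter)), so the two changes do not add up independently here: the same change on two cores in this assay, a number 11.7 percentage points lower (beyond the scatter) from compound 1 to compound 3 and a number 26.9 percentage points higher (beyond the scatter) from compound 2 to compound 4, 38.6 percentage points apart, beyond the scatter of two such steps.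

Among these compounds, this rests on only two matched pairs at a single tested concentration, so it shows that the step on one core cannot be relied on to predict the step on the other, but it neither explains the difference nor establishes a rule for the wider series.

The compounds shown leave open whether other groups in place of nitro, such as an amine or a carboxylic acid, would also behave differently on the two cores. They also leave open whether a longer chain in place of propyl would follow the propyl pair or the furan-2-yl pair.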